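This account rests on a few compounds, and the source may have more. Where it says the series, first, only, none or still open, it means among the compounds named here.

Working notes on the series.

Three compounds share a core and differ in the substituents carried on the benzylic ring. Compound 1 `COc1cccc(CNc2ncnc3c2ncn3C2CCCCO2)c1O`, compound 2 `COc1cc(CNc2ncnc3c2ncn3C2CCCCO2)ccc1O` and compound 3 `COc1ccc(CNc2ncnc3c2ncn3C2CCCCO2)cc1OC` have been run in an ADME assay on MCF7 cells (Homo sapiens) for cytotoxicity, with a stated time of 72 h; on this read-out lower numbers stand for stronger inhibition and higher numbers for weaker inhibition. In this assay compound 1 gives > 100000 nM, which is a limit of the assay and not a number. Compound 2 gives > 100000 nM in this assay, again a limit. Compound 3 gives > 100000 nM in this assay, also a limit.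

Going by the values given here, the one measured step within the set, a step that the two limits leave unreadable from compound 3 to compound 2, carries the change (hydrogen in place of methyl on an oxygen on an aromatic ring). Its size cannot be read, because of the limit of > 100000 nM in this assay, at which 3 of the 3 values shown sit. How the core of compound 1 differs from that of compound 3 is not broken down here.

Compound 4 `Oc1cccc(CNc2ncnc3c2ncn3C2CCCCO2)c1O` is not yet measured. It differs from compound 1 by hydrogen in place of methyl on an oxygen on an aromatic ring; the place is the same as in the step from compound 3 to compound 2, so this is the same change made a second time. The expected step from compound 1 to compound 4 in this assay is a step that the limit leaves unreadable from compound 1 to compound 4, and this expectation rests on compound 1 sitting at > 100000 nM and on the earlier step of the same change being unreadable because of the limit of > 100000 nM in this assay, at which 3 of the 3 values shown sit. For compound 4 the estimated value in this assay is 150000 nM, with a range from 50000 nM to 500000 nM, and the likelier outcome is that compound 4 again returns only a limit.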

Compound 4, half-maximal inhibitory concentration: > 100000 nM
Compound 4 ended at the assay's limit; the forecaster's own chance of this, stated with the estimate: 85%; the middle value does not contradict the limit.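

In this assay compound 4 gives > 100000 nM, a limit of the assay and not a number. The step from compound 1 to compound 4, methoxy to hydroxy, therefore yields no readable size, because of the following: the limit of > 100000 nM in this assay, at which 4 of the 4 values shown sit.

The compounds shown leave open whether any substituent on the benzylic ring has a readable effect in this assay, as none of them gives a number.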